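Bromo on the Core: Following Compound 1 to Compound 4

This account rests on a few compounds, and the source may have more. Where it says the series, first, only, none or still open, it means among the compounds named here.

Compound 1 `O=C(Cc1cccnc1)c1cc2ccccc2[nH]1`: 13%
Compound 2 `O=C(Cc1cnccn1)c1cc2ccccc2[nH]1`: "not active" (no number reported)
Compound 3 `O=C(Cc1ccccn1)c1cc2ccccc2[nH]1`: 10%

In an in vitro assay on P815B cells for inhibition of Indoleamine 2,3-dioxygenase 1 (Mus musculus), tested at 20 uM (a lower number here means less inhibition, a higher number more inhibition at the concentration tested (going by the name of the read-out)), compound 1 gives 13%, while compound 3 gives 10%; the two numbers sit within the scatter of each other, and compound 2 is reported without a number. For the measured compounds named here, the only step among measured compounds, a number 3 percentage points lower from compound 1 to compound 3 (within the scatter), concerns the pyridyl group and says nothing about a change on the core. Compound 4 `O=C(Cc1cccnc1)c1cc2cc(Br)ccc2[nH]1` differs from compound 1 by bromo in place of hydrogen on an aromatic carbon. Going by the values given here, no measured step bears on this change, so no step beyond the scatter is expected, and for compound 4 the estimate is 13% with a range from 0% to 35%, corresponding to an expected step of no change at the digits printed from compound 1 to compound 4 (within the scatter).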

Compound 4, a percentage reported as inhibition, at one concentration (the size of the read-out at that concentration, not a potency): "not active" (no number reported)
For compound 4 the study gives words and no number; there is nothing to compare the estimate with.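

For the compounds shown here, compound 4 carries no number in this assay, so no step from compound 1 to compound 4 can be read. The compounds shown leave open how far bromo in place of hydrogen shifts inhibition. No other measurement bears on this result.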